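A few compounds are considered here, and "the series" means these few. Any claim that something is new, unique, unknown or untested is made for them only; others in the source may bear on it.

Measured so far:
compound 1, `O=C(O)c1ccccc1-c1ccc(CCc2ncc(CC3CCOCC3)[nH]2)cc1`, 338 nM
compound 2, `CCCCc1cnc(CCc2ccc(-c3ccccc3C(=O)O)cc2)[nH]1`, 2710 nM

In an in vitro functional assay on cells for agonist activity at Bombesin receptor subtype-3 (Homo sapiens), read by luminescence and calcium flux (on this read-out lower numbers stand for an effect already at smaller amounts and higher numbers for an effect only at larger amounts of compound), compound 2 holds the highest of the two numbers; its nearest neighbour is compound 1, from which it differs by an 8.0-fold higher number from compound 1 to compound 2 (0.90 log units; beyond the scatter) when propyl replaces oxan-4-yl on a saturated chain carbon bound to an aromatic carbon. Compound 3, `O=C(O)c1ccccc1-c1ccc(CCc2ncc(-c3ccccc3)[nH]2)cc1`, is not yet measured. It arises from compound 2 by phenyl in place of butyl on an aromatic carbon. Among the compounds with values here, no measured step concerns a change at this aromatic carbon, and none swaps a chain for an aromatic ring, so the one step seen, from compound 1 to compound 2, bears on it only loosely: there, a ring-containing group gave the lower number and a plain chain the higher one. Taking that as a faint hint, a step downward of moderate size is expected, a 2.3-fold lower number from compound 2 to compound 3 (0.35 log units; beyond the scatter). The uncertainty is wide because compound 2 gives 2710 nM as the only anchor. For compound 3 the estimate in this assay is 1200 nM, within a range from 300 nM to 5000 nM.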

Compound 3, half-maximal effective concentration: 4950 nM
The estimate for compound 3 lay 4.1-fold (0.62 log units) below the measured number; low and high end bracket the measured number.
By their numbers in this assay, from the lowest: compound 1; then compounds 2 and 3 (each within the scatter of the next).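

In this assay, phenyl in place of butyl on this aromatic carbon gives a 1.8-fold higher number from compound 2 to compound 3 (0.26 log units; within the scatter), so a plain chain and a six-membered aromatic ring of carbon only cannot be told apart at this position. Phenyl in place of (oxan-4-yl)methyl gives a 15-fold higher number from compound 1 to compound 3 (1.17 log units; beyond the scatter), which shows that a ring as such does not go with the lower number: among the three groups seen here, only the (oxan-4-yl)methyl group of compound 1 stands clearly apart from the other two. No measurement at hand explains why this group differs from butyl and phenyl.

Going by these compounds, it remains open whether the lower number of compound 1 goes with the oxygen of the oxane ring or with the saturated carbon that joins that ring to the core, and a cyclohexylmethyl or a benzyl group on this aromatic carbon would help separate the two. Also open, on these data alone, is how a group carrying an amine or a hydroxyl would read at this position.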